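A few compounds are considered here, and "the series" means these few. Any claim that something is new, unique, unknown or untested is made for them only; others in the source may bear on it.

Of the compounds shown here, two of one chemical series have been tested in an assay on isolated protein for inhibition of Ectonucleotide pyrophosphatase/phosphodiesterase family member 1 (Homo sapiens), tested at 10 uM; a lower number here means less inhibition, a higher number more inhibition at the concentration tested (going by the name of the read-out). Compound 1, with the structure `COc1ccc(NC(=O)CSc2nc3ccc(OCC(F)(F)F)nc3[nH]2)cc1OC`, gives 61% in this assay, the higher of the two numbers obtained so far. Compound 2, with the structure `COc1cc(NC(=O)CSc2nc3cccnc3[nH]2)cc(OC)c1`, gives 38% in this assay, a number that lies a clear distance below that of compound 1, beyond the usual scatter of such measurements. Since compound 2 differs from compound 1 in more than one place, the two values alone do not tell which part of the structure accounts for the gap.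

Compound 3, with the structure `COc1ccc(NC(=O)CSc2nc3ccc(N(C)C)nc3[nH]2)cc1OC`, has not yet been tested. It differs from compound 1 in a single change: dimethylamino in place of 2,2,2-trifluoroethoxy on an aromatic carbon. Going by the values given here, no measured pair shows what a change of this kind does in this assay, so the expectation rests on compound 1 alone. The step from compound 1 to compound 3 is expected to be modest, a number 9 percentage points lower from compound 1 to compound 3 (within the scatter), and could fall on either side of the scatter. Compound 3 is accordingly estimated to give 52% in this assay, within a range from 28% to 74%.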

Compound 3, a percentage reported as inhibition, at one concentration (the size of the read-out at that concentration, not a potency): 58%
The estimate for compound 3 lay 6 percentage points below the measured number; low and high end bracket the measured number.
By their numbers in this assay, from the lowest: compound 2; then compounds 3 and 1 (each within the scatter of the next).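

In this assay, putting dimethylamino in place of 2,2,2-trifluoroethoxy on this aromatic carbon gives a number 3 percentage points lower from compound 1 to compound 3 (within the scatter), so compound 1 and compound 3 cannot be told apart in this measurement. Going by these compounds alone, this is the first pair that differs in one place only, and the swap is not a small one: a group of 6 heavy atoms containing oxygen and fluorine gives way to one of 3 heavy atoms containing nitrogen, so for this pair, neither the fluorine atoms nor the ether oxygen of the departing group is required to keep the inhibition at this level. Nothing measured here gives a reason for the two compounds standing so close together.

The compounds shown leave open what happens on the core of compound 1 with only a hydrogen on this carbon, which would show whether a group here matters at all. They also leave open how a larger amine such as morpholine, a longer chain such as butoxy, or a carboxylic acid would fare at the same place.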